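The compounds below may be only part of what the source reports. "The series", "measured", "known", "first", "only" and "open" are said of these compounds alone.

The compounds measured in a functional assay for inhibition, with Homo sapiens as the target (a higher number here means a weaker inhibitor, a lower number a stronger inhibitor), so far:
compound 1, `Cc1cccc(Nc2nccc(-c3cccs3)n2)c1`, gives 300 nM.
compound 2, `CN(C)c1cccc(Nc2nccc(-c3ccncc3)n2)c1`, gives 3700 nM.
compound 3, `Cc1cc(-c2ccncc2)nc(Nc2cccc(N(C)C)c2)n1`, gives > 24000 nM.

Of the two compounds with a number, compound 1 has the lower one and compound 2 the higher. Compound 1 and compound 2 differ in their cores, and that difference is not broken down here. The result for compound 3 is a limit of this assay and not a number: the limit of > 24000 nM in this assay, at which 1 of the 3 values shown sits.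

Compound 2 and compound 3 differ in one place, (methyl in place of hydrogen on an aromatic carbon). This change produced an at least 6.4-fold higher number from compound 2 to compound 3 (0.81 log units; beyond the scatter).

The unmeasured compound 4, `Cc1cc(C)cc(Nc2nccc(-c3cccs3)n2)c1`, differs from compound 1 as follows: methyl in place of hydrogen on an aromatic carbon. Among the measured compounds shown here, this is the same kind of change as the one from compound 2 to compound 3, but not the same: there the methyl entered a six-membered aromatic ring with 2 nitrogen, next to the ring nitrogen, meta to a pyridin-4-yl group and opposite the ring nitrogen, while here it enters a six-membered aromatic ring of carbon only, meta to a methyl group. For the measured compounds named here, because the only measured example, an at least 6.4-fold higher number from compound 2 to compound 3 (0.81 log units; beyond the scatter), sits on a different ring, the step expected for compound 4 is smaller, a 1.5-fold higher number from compound 1 to compound 4 (0.18 log units; within the scatter). For compound 4 the expected value is 450 nM. For compound 4 the estimate spans from 130 nM to 1600 nM.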

Compound 4, half-maximal inhibitory concentration: 4300 nM
Beside the measured number, compound 4's estimate is 9.6-fold (0.98 log units) below it; measured number outside the range, above it.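

In this assay, a second methyl on the ring of carbon only made compound 1 clearly weaker, with a 14-fold higher number from compound 1 to compound 4 (1.16 log units; beyond the scatter). Set beside the earlier step, the same kind of change raised the number on both cores, so in these two cases a methyl in place of a hydrogen on an aromatic carbon went with weaker inhibition, and no listed pair goes against this, though two pairs are a very small sample: the same change on two cores in this assay, an at least 6.4-fold higher number (0.81 log units; beyond the scatter) from compound 2 to compound 3 and a 14-fold higher number (1.16 log units; beyond the scatter) from compound 1 to compound 4; the limit leaves it open whether they differ. This does not show that the size of the step carries from one core to another, since the methyl enters a different ring in each pair and compound 3 gives only a limit of the assay and not a number, which leaves the size of its step unknown: the limit of > 24000 nM in this assay, at which 1 of the 4 values shown sits.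

The compounds shown leave open whether a fluorine, a chlorine or a methoxy group in the place of the new methyl of compound 4 would raise the number as well. They also leave open what a methyl would do on the core of compound 1 at the place it took in compound 3, and what a methyl would do on the core of compound 2 at the place it took in compound 4.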